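Chloro in place of methyl on the aryl ring

The source may report more compounds than this note shows. Statements on the series, on what has been measured and on what is new or still open speak of the compounds shown alone.

Compound 3 `Cc1cc(-n2cc(C(=O)Nc3cc(F)cc(F)c3)c(=O)c3ccc(N(C)C)nc32)ccc1OCCCCCCC[N+]1(C)CCCCC1` gives 54.4% in an assay on LX2 cells for inhibition of COL1A1 promoter (Homo sapiens), read by a luciferase reporter, with a stated time of 24 h, tested at 50 uM (on this read-out lower numbers stand for a weaker effect and higher numbers for a stronger effect at the one concentration tested), the highest of the three numbers; compound 1 `CN(C)c1ccc2c(=O)c(C(=O)Nc3cc(F)cc(F)c3)cn(-c3ccc(OCCCCCCC[N+]45CCN(CC4)CC5)c(Cl)c3)c2n1` gives 20.5% and compound 2 `CN(C)c1ccc2c(=O)c(C(=O)Nc3cc(F)cc(F)c3)cn(-c3ccc(OCCCCCCC[N+]4(C)CCCC4)c(Cl)c3)c2n1` gives 2.59%, both beyond the scatter from compound 3. Among the measured compounds shown here, the only measured step, a number 17.9 percentage points lower from compound 1 to compound 2 (beyond the scatter), concerns the charged end of the chain, not the aromatic carbon. Compound 4 `CN(C)c1ccc2c(=O)c(C(=O)Nc3cc(F)cc(F)c3)cn(-c3ccc(OCCCCCCC[N+]4(C)CCCCC4)c(Cl)c3)c2n1` differs from compound 3 by chloro in place of methyl on an aromatic carbon. For the measured compounds named here, no measured step bears on this change, so its size is open. Compound 4 carries the chloro seen in compound 1 at 20.5% and compound 2 at 2.59%, both well under compound 3. Compound 4 is therefore expected to step down by a number 24.4 percentage points lower from compound 3 to compound 4 (beyond the scatter). Compound 4 is estimated at 30%, within 5% to 60%.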

Compound 4, a percentage reported as inhibition, at one concentration (the size of the read-out at that concentration, not a potency): "not active" (no number reported)
Compound 4: no number reported; there is nothing to compare the estimate with.
By their numbers in this assay, from the lowest: compound 2; then compound 1; then compound 3.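

Among the compounds shown here, compound 4 is reported as "not active" with no number, so no step from compound 3 to compound 4 can be read. The compounds shown leave open the size of the change from methyl to chloro, and no supporting data bear on this result.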